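Extending a Pyrimidine Side Chain Toward Toll-like Receptor 8 Agonism

A few compounds are considered here, and "the series" means these few. Any claim that something is new, unique, unknown or untested is made for them only; others in the source may bear on it.

Measured compounds:
- compound 1, `CCCCNc1nc(N)nc(C)c1C`: 3280 nM
- compound 2, `CCCCNc1nc(N)nc(C)c1CCCN1CCN(c2ccccc2)CC1`: 92 nM

Among the measured compounds shown here, in an assay on HEK293 cells for agonist activity at Toll-like receptor 8 (Homo sapiens), read by spectrophotometry (on this read-out higher numbers stand for an effect only at larger amounts of compound and lower numbers for an effect already at smaller amounts), compound 1 gives 3280 nM, the higher of the two numbers so far. Compound 2 gives 92 nM in this assay, a lower number, and the gap between the two lies beyond the usual scatter. Compound 2 carries a long chain on the shared core where compound 1 carries only hydrogen.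

Compound 3, `CCCCNc1nc(N)nc(C)c1CCCn1cncn1`, has not yet been measured. It differs from compound 1 by 2-(1H-1,2,4-triazol-1-yl)ethyl in place of hydrogen on a saturated chain carbon bound to an aromatic carbon. For the measured compounds named here, no measured pair shows this exact change, so the size of the step is uncertain. Because compound 2 gives 92 nM with a chain at the same place, a move toward lower numbers is expected for compound 3, though probably smaller than compound 2 shows. The step from compound 1 to compound 3 is estimated at a 4.1-fold lower number from compound 1 to compound 3 (0.61 log units; beyond the scatter). Compound 3 is expected to give about 800 nM, within 200 nM to 3200 nM.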

Compound 3, half-maximal effective concentration: 1050 nM
Compound 3: the middle estimate sits 1.3-fold (0.12 log units) below what was measured; the range from low to high includes it.
By their numbers in this assay, from the lowest: compound 2; then compound 3; then compound 1.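

In this assay, a chain ending in a five-membered aromatic ring with 3 hetero atoms also lowers the number when placed on this saturated chain carbon bound to an aromatic carbon, with a 3.1-fold lower number from compound 1 to compound 3 (0.49 log units; beyond the scatter). The drop is therefore not unique to the chain of compound 2, but its size depends on what the chain carries: compound 3 gives 1050 nM, while compound 2 gives 92 nM. No outside data bear on this result, so the gap between the two chains remains unexplained.

The compounds shown leave open how much of the drop comes from the chain itself and how much from the group at its end. A plain propyl chain, a longer chain carrying the same triazole, or a chain ending in a simple amine would help separate these contributions.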